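From Methoxy to Methyl: Expecting Little Change

A few compounds are considered here, and "the series" means these few. Any claim that something is new, unique, unknown or untested is made for them only; others in the source may bear on it.

Compound 3 `COc1ccc(-c2nc3sc(Cc4ccc(Cl)cc4)nn3c2SC#N)cc1` carries a thiocyanate group on its shared core and a methoxy on the outer benzene ring. In a functional assay on HeLa cells (Homo sapiens) for cytotoxicity, with a stated time of 72 h (on this read-out lower numbers stand for stronger inhibition and higher numbers for weaker inhibition), compound 3 gives 9000 nM, the lowest of the two numbers recorded. Its nearest neighbour is compound 2 `Cc1ccc(-c2nc3sc(Cc4ccc(Cl)cc4)nn3c2C=O)cc1`, which has a formyl where compound 3 has the thiocyanate and a methyl where compound 3 has the methoxy; in this assay compound 2 gives 21000 nM. Compound 1 `Cc1ccc(-c2cn3nc(Cc4ccc(Cl)cc4)sc3n2)cc1` has only a hydrogen where compound 2 has the formyl. In this assay compound 1 reaches only > 250000 nM, which is a limit of the assay and not a number (the limit of > 250000 nM in this assay, at which 1 of the 3 values shown sits). Within the data shown here, the single step between measured compounds, an at least 11-fold lower number from compound 1 to compound 2 (1.07 log units; beyond the scatter), concerns the formyl and says nothing about the outer ring. Compound 4 `Cc1ccc(-c2nc3sc(Cc4ccc(Cl)cc4)nn3c2SC#N)cc1` differs from compound 3 in one place: methyl in place of methoxy on an aromatic carbon. Among the measured compounds shown here, no measured step covers this exchange, so no change beyond the scatter is expected. The step of no change at the digits printed from compound 3 to compound 4 (within the scatter) is therefore estimated as small. Compound 4 is expected to give 9000 nM, with a range from 3000 nM to 27000 nM.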

Compound 4, half-maximal inhibitory concentration: 22000 nM
Compound 4: the middle estimate sits 2.4-fold (0.39 log units) below what was measured; the measured number falls inside the stated range.
By their numbers in this assay, from the lowest: compound 3; then compounds 2 and 4 (each within the scatter of the next). At a limit, above all of these: compound 1.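

Among these compounds, the outer benzene ring, which no earlier step touched, does count in this assay: with the thiocyanate held constant, going from 4-methoxyphenyl to 4-methylphenyl gives a 2.4-fold higher number from compound 3 to compound 4 (0.39 log units; beyond the scatter). With the methyl held constant on that ring, cyanosulfanyl in place of formyl on the core gives a 1.0-fold higher number from compound 2 to compound 4 (0.02 log units; within the scatter), so this read-out does not tell these two groups apart. Cyanosulfanyl in place of hydrogen gives an at least 11-fold lower number from compound 1 to compound 4 (1.05 log units; beyond the scatter), much like the formyl step, but compound 1 stands at a limit and not at a number: the limit of > 250000 nM in this assay, at which 1 of the 4 values shown sits.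

From the compounds shown here alone, whether methoxy in place of methyl gives a similar step with a formyl on the core remains open. Also open, going by these compounds, is how a hydroxyl, an amine or a longer ether chain would read at this place on the outer ring.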